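This account rests on a few compounds, and the source may have more. Where it says the series, first, only, none or still open, it means among the compounds named here.

Three compounds share a bicyclic sugar-derived scaffold carrying a benzylidene-type acetal, and they were followed in a functional assay on HEL cells (Homo sapiens) for cytotoxicity; on this read-out higher numbers stand for lower toxicity in this test and lower numbers for higher toxicity in this test. Compound 1, `C=CC[C@@H]1O[C@@H]2CO[C@@H](c3ccccc3)O[C@H]2[C@H](OC)[C@H]1OC`, has as its entry in this assay "not determined" (no result reported), so no number is available for it. Compound 2, `CO[C@@H]1[C@@H](OC)[C@H](Cc2ccccc2)O[C@@H]2CO[C@@H](c3ccccc3)O[C@@H]12`, gives 20 ug/mL in this assay. Compound 3, `O=[N+]([O-])c1ccc([C@@H]2OC[C@H]3O[C@@H](c4ccccc4)[C@H](O)[C@@H](O)[C@@H]3O2)cc1`, gives 50 ug/mL in this assay, the highest of the two numbers available; the gap to compound 2 lies beyond the usual scatter of repeated measurements, so compound 3 comes out as the less toxic of the two measured compounds.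

Compound 4, `O[C@@H]1[C@@H](O)[C@H](c2ccccc2)O[C@@H]2CO[C@@H](c3ccc(Cl)cc3)O[C@@H]12`, is the next compound in line and has not yet been measured in this assay. Compared with compound 3 it differs in one place: chloro in place of nitro on an aromatic carbon. Among the measured compounds shown here, no pair of measured compounds shows a step of this kind, so there is nothing to read the direction from directly. Since the change swaps one substituent for another on the same aromatic ring without touching the core, the step from compound 3 to compound 4 is expected to be small, a 1.3-fold lower number from compound 3 to compound 4 (0.10 log units; within the scatter), most likely within the scatter or only slightly toward a lower number. Compound 4 is therefore estimated at 40 ug/mL in this assay, with a range from 15 ug/mL to 100 ug/mL.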

Compound 4, minimum cytotoxic concentration: >= 100 ug/mL
Compound 4 was reported as a limit; the forecaster's own chance of this, stated with the estimate: 20%; middle value at least 2.5-fold (0.39 log units) away from the limit.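

In this assay compound 4 carries >= 100 ug/mL, which is a limit and not a number. Swapping 4-nitrophenyl for 4-chlorophenyl gives an at least 2.0-fold higher number from compound 3 to compound 4 (0.30 log units; that floor lies within the scatter), the first reading of any change at this place on the aromatic ring, and it shows that losing the nitro group in favour of chloro brings no move toward a lower number, although the floor of the step alone does not clear the scatter, so a real rise is suggested rather than established. The whole reading of this step therefore rests on one limit: the limit of >= 100 ug/mL in this assay, at which 1 of the 4 values shown sits.

The compounds shown leave open how far the true value of compound 4 lies from that of compound 3, and whether any other group at this place, such as an amine, a carboxylic acid or plain hydrogen, would fall on the same side as chloro or with nitro. They also leave open whether the same swap of nitro for chloro would read the same way on a core bearing the methoxy groups of compound 2 rather than the free hydroxyl groups of compound 3 and compound 4.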